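This account rests on a few compounds, and the source may have more. Where it says the series, first, only, none or still open, it means among the compounds named here.

Measured so far in an ADME assay on HepG2 cells (Homo sapiens) for cytotoxicity, read by luminescence, CellTiter-Glo and ATP content, with a stated time of 72 h; on this read-out higher numbers stand for an effect only at larger amounts of compound and lower numbers for an effect already at smaller amounts:
compound 1 `COc1ccc(-c2ccc3c(NCCCNCc4cccc(OC)c4O)ccnc3c2)cc1`, 1600 nM
compound 2 `COc1ccc(F)cc1CNCCCNc1ccnc2cc(-c3ccc(F)cc3)ccc12`, 770 nM
compound 3 `COc1ccc(-c2ccc3c(NCCCNCc4cc(F)ccc4OC)ccnc3c2)cc1`, 5960 nM

Among these three, compound 1 stands second highest: compound 2 gives a lower number, and the step of a 3.7-fold higher number from compound 1 to compound 3 (0.57 log units; beyond the scatter) runs upward. The unmeasured compound 4 `COc1cccc(CNCCCNc2ccnc3cc(CCc4ccccc4)ccc23)c1O` differs from compound 1 at the shared core, (phenethyl in place of 4-methoxyphenyl on an aromatic carbon). The two measured steps, a 3.7-fold higher number from compound 1 to compound 3 (0.57 log units; beyond the scatter) and a 7.7-fold higher number from compound 2 to compound 3 (0.89 log units; beyond the scatter), both concern the substituent on the saturated chain carbon bound to the amine nitrogen, not the aromatic carbon of the core; neither bears directly on this change. Going by the values given here, no measured pair therefore informs the step to compound 4, and the expectation is a step within the scatter, with wide uncertainty. For compound 4 the expected number in this assay is 1600 nM, within 550 nM to 4700 nM. The expected step is no change at the digits printed from compound 1 to compound 4 (within the scatter).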

Compound 4, half-maximal effective concentration: 6800 nM
Beside the measured number, compound 4's estimate is 4.3-fold (0.63 log units) below it, outside the stated range (above it).
By their numbers in this assay, from the lowest: compound 2; then compound 1; then compounds 3 and 4 (each within the scatter of the next).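

In this assay, going by these compounds alone, the earlier steps changed only the group on the saturated chain carbon, whereas this one shows that the aromatic carbon of the shared core also matters: phenethyl in place of 4-methoxyphenyl gives a 4.3-fold higher number from compound 1 to compound 4 (0.63 log units; beyond the scatter). The two groups have the same heavy-atom count and each holds one six-membered aromatic ring of carbon only, yet the number still moves beyond the scatter. No evidence here accounts for this shift.

As far as these compounds go, it remains open whether phenethyl would act alike with the 5-fluoro-2-methoxyphenyl group on the chain. Also open, from the compounds shown here alone, is what a benzyl group or an unsubstituted phenyl would give on this aromatic carbon.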